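From phenoxy to chloro: a step yet to be measured

A few compounds are considered here, and "the series" means these few. Any claim that something is new, unique, unknown or untested is made for them only; others in the source may bear on it.

Among the compounds with values here, in an ADME assay for permeability, using PAMPA, at pH 7.4 (on this read-out lower numbers stand for lower permeability and higher numbers for higher permeability), compound 2 (`CCOC(=O)c1c(-c2cccc(Oc3ccccc3)c2)[nH]c2cc(OC)ccc2c1=O`) gives 750 10^-6 cm/s, the highest of the two numbers so far. Compound 1 (`CCCOc1cccc(-c2[nH]c3cc(OC)ccc3c(=O)c2C(=O)OCC)c1`) gives 340 10^-6 cm/s. The next molecule, compound 3 (`CCOC(=O)c1c(-c2cccc(Cl)c2)[nH]c2cc(OC)ccc2c1=O`), keeps the shared core but carries a different group: chloro in place of phenoxy on an aromatic carbon. Within the data shown here, only one measured step bears on this change: a 2.2-fold higher number from compound 1 to compound 2 (0.34 log units; beyond the scatter), a modest move seen when phenyl took the place of propyl on an oxygen on an aromatic ring. That swap is not the same as this one, so it offers only rough guidance. Here the phenoxy leaves altogether, so a modest move the opposite way seems the likeliest outcome. The expected change in this assay is a 1.9-fold lower number from compound 2 to compound 3 (0.27 log units; within the scatter). Compound 3 is estimated at 400 10^-6 cm/s, with an expected range from 170 10^-6 cm/s to 850 10^-6 cm/s.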

Compound 3, apparent permeability: 950 10^-6 cm/s
Beside the measured number, compound 3's estimate is 2.4-fold (0.38 log units) below it; measured number outside the range, above it.
By their numbers in this assay, from the lowest: compound 1; then compounds 2 and 3 (each within the scatter of the next).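

On this aromatic carbon, the step in this assay is a 1.3-fold higher number from compound 2 to compound 3 (0.10 log units; within the scatter) and so gives no sign of a real difference, even though the phenoxy group with its whole six-membered ring is replaced by a single chlorine atom. Replacing propoxy with chloro at the same place is another matter: it gives a 2.8-fold higher number from compound 1 to compound 3 (0.45 log units; beyond the scatter) and this, with the earlier step to compound 2, sets compound 1 apart from the other two compounds. The data offer no measured explanation for either step.

Three groups at one place are too few to show what sets the number here, and a basic amine or a carboxylic acid on this carbon could behave quite differently. As far as these compounds go, whether chloro would give the same result elsewhere on this ring also remains open.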